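Swapping the 3-methylphenyl group of compound 3

This account rests on a few compounds, and the source may have more. Where it says the series, first, only, none or still open, it means among the compounds named here.

In a functional assay on A549 cells (Homo sapiens) for inhibition, read by CCK-8 assay, with a stated time of 48 h (a higher number here means a weaker inhibitor, a lower number a stronger inhibitor), compound 1 (`COc1cc(-c2ccnc3cc(-c4ccc(C)c(C)c4)nn23)cc(OC)c1OC`) gives 272 nM, compound 2 (`C=Cc1ccc(-c2cc3nccc(-c4cc(OC)c(OC)c(OC)c4)n3n2)cc1`) gives 1030 nM and compound 3 (`COc1cc(-c2ccnc3cc(-c4cccc(C)c4)nn23)cc(OC)c1OC`) gives 5730 nM, the highest number of the three. Compound 4 (`COc1ccc(-c2cc3nccc(-c4cc(OC)c(OC)c(OC)c4)n3n2)cc1F`) changes only the group on the aromatic carbon of the five-membered ring: 3-fluoro-4-methoxyphenyl in place of 3-methylphenyl on an aromatic carbon. Two measured steps at this carbon bear on it: a 21-fold higher number from compound 1 to compound 3 (1.32 log units; beyond the scatter), which is large, and a 5.6-fold higher number from compound 2 to compound 3 (0.75 log units; beyond the scatter), which is modest. Neither compound 1 nor compound 2 carries fluorine or methoxy, so the precedent is indirect. The expected step is a 7.2-fold lower number from compound 3 to compound 4 (0.86 log units; beyond the scatter), toward a stronger inhibitor, and of modest size. Compound 4 is estimated at 800 nM, with an expected range of 180 nM to 3500 nM.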

Compound 4, half-maximal inhibitory concentration: 545 nM
Estimate against measurement, compound 4: 1.5-fold (0.17 log units) above, and the stated range covers the measured number.
By their numbers in this assay, from the lowest: compounds 1, 4 and 2 (each within the scatter of the next, the first and the last beyond it); then compound 3.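

In this assay, among these compounds, the 3-fluoro-4-methoxyphenyl group, the only group here with a hydrogen-bond acceptor, gives an 11-fold lower number from compound 3 to compound 4 (1.02 log units; beyond the scatter) at this carbon of the five-membered ring, so this position accepts an oxygen-bearing, fluorinated phenyl without loss against 3-methylphenyl. Compound 4 cannot be separated from its two neighbours: both a 1.9-fold lower number from compound 2 to compound 4 (0.28 log units; within the scatter) and a 2.0-fold higher number from compound 1 to compound 4 (0.30 log units; within the scatter) lie within the scatter. Nothing measured here accounts for these steps.

Still open, as far as these compounds go, is whether the fluorine or the methoxy carries the step from 3-methylphenyl. Also open, from the compounds shown here alone, is how an amine or a carboxylic acid on this phenyl ring would read in this assay at this carbon.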